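Pyridine for Furan on a Sulfonyl Hydrazone Core

This account rests on a few compounds, and the source may have more. Where it says the series, first, only, none or still open, it means among the compounds named here.

Of the compounds shown here, two built on the same core have been measured. Compound 1 `C/C(=N\NC(=O)c1cccc(S(=O)(=O)N2CCOCC2)c1)c1ccc(F)cc1` was tested in a functional assay on EC9706 cells (Homo sapiens) for antiproliferative activity, read by MTT assay, with a stated time of 72 h; a higher number here means a weaker inhibitor, a lower number a stronger inhibitor. In this assay compound 1 gives > 100000 nM, which is a limit of the assay rather than a number. Compound 2 `O=C(N/N=C/c1ccco1)c1cccc(S(=O)(=O)N2CCOCC2)c1` carries a furan-2-yl on the carbon with a double bond to nitrogen. In this assay compound 2 gives > 100000 nM, again a limit and not a number. Among the measured compounds shown here, compound 2 therefore stands at the limit of > 100000 nM in this assay, at which 2 of the 2 values shown sit, together with the only other value shown, and no step between measured compounds is available.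

Compound 3 `O=C(N/N=C/c1ccccn1)c1cccc(S(=O)(=O)N2CCOCC2)c1` is the compound not yet measured. It differs from compound 2 in one place: pyridin-2-yl in place of furan-2-yl on a carbon with a double bond to nitrogen.

Since neither measured compound moved off the limit, no step beyond the scatter is expected in this assay, in either direction. The expected step is a number no higher from compound 2 to compound 3 (the limit leaves the size open). Compound 3 is expected to give about 100000 nM in this assay, within a range from 30000 nM to 300000 nM, and most likely the assay would again report only a limit.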

Compound 3, half-maximal inhibitory concentration: 44300 nM
Compound 3: middle estimate off by 2.3-fold (0.35 log units), on the high side; low and high end bracket the measured number.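

In this assay, replacing the furan-2-yl group with pyridin-2-yl gives an at least 2.2-fold lower number from compound 2 to compound 3 (0.35 log units; beyond the scatter), so the group at this place can change the read-out on this core. Among the compounds shown here, this is something the earlier compounds could not show, and compound 3, at 44300 nM, is the only one of the three with an actual number, which gives later changes at this place a value to be compared with. The true size of the step stays open because compound 2 has no number of its own, only a limit: the limit of > 100000 nM in this assay, at which 2 of the 3 values shown sit.

The change swaps a five-membered ring with an oxygen for a six-membered ring with a nitrogen, so these compounds cannot separate the effect of ring size from that of the hetero atom, and a plain phenyl ring at the same place would help to tell the two apart. Nor do they show whether the placement of the ring nitrogen matters, a question that pyridin-3-yl and pyridin-4-yl could address.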